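Two Nitrile Chains Replace the Methylphenyl Amide

The compounds below may be only part of what the source reports. "The series", "measured", "known", "first", "only" and "open" are said of these compounds alone.

Measured compounds:
Compound 1, `CCn1c(C(=O)NCCN(C)C)ccc1C(CC)(CC)c1ccc(OCC(O)C(C)(C)C)c(C)c1`: 14 nM
Compound 2, `CCn1c(C(=O)NCC(OC)OC)ccc1C(CC)(CC)c1ccc(OCC(O)C(C)(C)C)c(C)c1`: 150 nM
Compound 3, `CCn1c(C(=O)N(C)c2ccccc2)ccc1C(CC)(CC)c1ccc(OCC(O)C(C)(C)C)c(C)c1`: 6400 nM

In an assay on HL-60 cells for agonist activity at vitamin D3 receptor (Homo sapiens), read by microscopy, with a stated time of 96 h (a higher number here means that more compound is needed for the effect, a lower number that less compound is needed), compound 3 gives 6400 nM, the highest of the three numbers. Its nearest neighbour is compound 2 with 150 nM, and the gap is a 43-fold higher number from compound 2 to compound 3 (1.63 log units; beyond the scatter). Compound 1 lies furthest away with 14 nM, a gap of a 460-fold higher number from compound 1 to compound 3 (2.66 log units; beyond the scatter). Both steps into compound 3 therefore went strongly upward, and both replaced a substituted amino group on the carbonyl carbon with methyl(phenyl)amino.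

Compound 4, `CCn1c(C(=O)N(CCC#N)CCC#N)ccc1C(CC)(CC)c1ccc(OCC(O)C(C)(C)C)c(C)c1`, is not yet measured. Its change from compound 3 is a group of 9 heavy atoms (6 carbon, 3 nitrogen; no ring) in place of a group of 8 heavy atoms (7 carbon, 1 nitrogen; one six-membered aromatic ring of carbon only), on a carbonyl carbon. The two measured steps that bear on it are a 460-fold higher number from compound 1 to compound 3 (2.66 log units; beyond the scatter) and a 43-fold higher number from compound 2 to compound 3 (1.63 log units; beyond the scatter), both large and both arriving at the methyl(phenyl)amino group that now leaves. Among the measured compounds shown here, neither gives a step that starts from compound 3, and no measured compound carries a nitrile, so the direction can only be inferred loosely: the group that enters carries no ring and two hydrogen-bond acceptors, which in this set resembles the groups of compound 1 and compound 2 more than that of compound 3. A moderate downward step, a 3.2-fold lower number from compound 3 to compound 4 (0.51 log units; beyond the scatter), is therefore expected, though with wide uncertainty. The estimate for compound 4 in this assay is 2000 nM, with a range of 300 nM to 15000 nM.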

Compound 4, half-maximal effective concentration: 97 nM
For compound 4 the middle estimate is 21-fold (1.31 log units) above the measured one; measured number outside the range, below it.
By their numbers in this assay, from the lowest: compound 1; then compounds 4 and 2 (each within the scatter of the next); then compound 3.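

In this assay the step of a 66-fold lower number from compound 3 to compound 4 (1.82 log units; beyond the scatter) shows that this position on the carbonyl carbon can hold a fully substituted amide nitrogen without the high number of compound 3, once the methyl(phenyl)amino group gives way to a group with no ring and two nitrile chains. The earlier compounds could not separate the loss of the amide hydrogen from the arrival of the phenyl ring, but compound 4 also lacks that hydrogen and still shows a 1.5-fold lower number from compound 2 to compound 4 (0.19 log units; within the scatter), so the missing amide hydrogen alone does not account for the number of compound 3. A real gap remains to the (2-(dimethylamino)ethyl)amino group, with a 6.9-fold higher number from compound 1 to compound 4 (0.84 log units; beyond the scatter), and nothing in the data offers a reason for this gap or the others.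

From the compounds shown here alone, whether a (2-cyanoethyl)amino group, with one nitrile chain and the amide hydrogen kept, would come closer to compound 1 stays open. So does whether the aromatic ring itself matters, which a methyl(cyclohexyl)amino group on the same carbonyl carbon would address.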